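The source may hold more compounds than are shown below. What is called first, only, known or untested is meant among the compounds shown, and "the series" means these compounds.

Measured so far:
compound 1, `CC1CCN(C2CCN(S(=O)(=O)c3cccnc3F)CC2)CC1`: > 5000 nM
compound 2, `CC1CCN(C2CCN(S(=O)(=O)c3cc(Br)cc4c3OCC4)CC2)CC1`: 96 nM

Compound 1 stands at the limit of > 5000 nM in this assay, at which 1 of the 2 values shown sits; its value is a limit of the assay, not a number. Within the data shown here, compound 2 is the only one with a measured number. Compound 3, `CC1CCN(C2CCN(S(=O)(=O)c3cccc(Br)c3)CC2)CC1`, differs from compound 1 by 3-bromophenyl in place of 2-fluoropyridin-3-yl on a sulfonyl sulfur. In a functional assay on DLD-1 cells (Homo sapiens) for antiproliferative activity, read by CellTiter-Glo, with a stated time of 72 h (on this read-out lower numbers stand for stronger inhibition and higher numbers for weaker inhibition), the step from compound 1 to compound 3 is expected to run towards stronger inhibition, beyond the scatter, since compound 2 with 96 nM shows that a bromine-bearing aryl on this sulfonyl can give a measurable value. Compound 3 is estimated at 1500 nM, range 300 nM to 5000 nM, an expected step of an at least 3.3-fold lower number from compound 1 to compound 3 (0.52 log units; beyond the scatter).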

Compound 3, half-maximal inhibitory concentration: 3.2 nM
Compound 3: middle estimate off by 470-fold (2.67 log units), on the high side; measured number below the stated range.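

On the sulfonyl sulfur, a change of the aryl group alone moves the series from inactive to highly potent in this assay: 3-bromophenyl in place of 2-fluoropyridin-3-yl gives an at least 1500-fold lower number from compound 1 to compound 3 (3.19 log units; beyond the scatter). The full size of this step cannot be read because compound 1 has a limit, not a number: the limit of > 5000 nM in this assay, at which 1 of the 3 values shown sits.

This single change alters the ring nitrogen, the fluorine and the bromine together, and their separate shares remain unresolved. Also open, as far as these compounds go, is whether plain phenyl, 3-chlorophenyl or 3-methoxyphenyl on the sulfonyl sulfur would keep the value of compound 3.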